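Carbamate series: chain extension and lipophilicity

The source may hold more compounds than are shown below. What is called first, only, known or untested is meant among the compounds shown, and "the series" means these compounds.

Measured so far in a physicochemical assay for lipophilicity; on this read-out lower numbers stand for lower lipophilicity and higher numbers for higher lipophilicity:
compound 1, `CCCCCCCCNC(=O)Oc1ccc(Cl)cc1C(=O)Nc1cccc(Cl)c1`, gives 6.36
compound 2, `CCCCCCCCCCNC(=O)Oc1ccc(Cl)cc1C(=O)Nc1cccc(Cl)c1`, gives 7.19
compound 3, `CCNC(=O)Oc1ccc(Cl)cc1C(=O)Nc1ccc(Cl)c(Cl)c1`, gives 4.35

Compound 3 stands lowest of the three; the difference between its core and the core of compound 1 is not broken down here. The step of a number 0.83 log units higher from compound 1 to compound 2 (beyond the scatter) comes from ethyl in place of hydrogen on a saturated chain carbon, eight bonds along the chain from an amide-type nitrogen. Compound 4, `CCCCNC(=O)Oc1ccc(Cl)cc1C(=O)Nc1ccc(Cl)c(Cl)c1`, is not yet measured in this assay; it differs from compound 3 by ethyl in place of hydrogen on a saturated chain carbon, two bonds along the chain from an amide-type nitrogen. This is the same kind of change as from compound 1 to compound 2, but the place differs: eight bonds along the chain from an amide-type nitrogen there, two bonds along the chain from an amide-type nitrogen here. Resting on the step of a number 0.83 log units higher from compound 1 to compound 2 (beyond the scatter), a step of about a number 0.85 log units higher from compound 3 to compound 4 (beyond the scatter) is expected for compound 4 in this assay. Compound 4 is therefore estimated at 5.2, between 4.7 and 5.7.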

Compound 4, partition coefficient: 5.25
The estimate for compound 4 lay 0.05 log units below the measured number; the measured number falls inside the stated range.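

In this assay, ethyl in place of hydrogen on a saturated chain carbon, two bonds along the chain from an amide-type nitrogen, gives a number 0.90 log units higher from compound 3 to compound 4 (beyond the scatter), a modest step, as is a number 0.83 log units higher from compound 1 to compound 2 (beyond the scatter) on the other core, eight bonds along the chain. The change therefore carried over between these two cores with a step of modest size in both pairs, but this rests on two pairs only, and core and place differ together, so their separate contributions cannot be read. Nothing available explains the size of either step.

The compounds shown leave open whether the step would hold for an amine or a carboxylic acid on the chain in place of the added ethyl. They also leave open how a branched chain would behave on either core.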